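Fluoro for Hydrogen Repeated in an Antiproliferative Series

The source may report more compounds than this note shows. Statements on the series, on what has been measured and on what is new or still open speak of the compounds shown alone.

compound 1 `O=C(NOCc1ccccc1)c1cn(-c2ccccc2)nc1-c1ccc(Cl)cc1`: 13000 nM
compound 2 `O=C(NOCc1ccccc1F)c1cn(-c2ccccc2)nc1-c1ccc(Cl)cc1`: 12100 nM
compound 3 `O=C(NOCc1ccccc1)c1cn(-c2ccccc2)nc1-c1ccc(F)cc1`: 10400 nM

In a functional assay on A549 cells (Homo sapiens) for antiproliferative activity, read by MTT assay, with a stated time of 48 h, in the presence of a further agent that is not named here (a higher number here means a weaker inhibitor of growth, a lower number a stronger inhibitor of growth), the three measured compounds sit close together. Compound 2 differs from compound 1 by fluoro in place of hydrogen on an aromatic carbon, and this gave a 1.1-fold lower number from compound 1 to compound 2 (0.03 log units; within the scatter). Compound 3 differs from compound 1 in its core by fluoro in place of chloro on an aromatic carbon, which gave a 1.3-fold lower number from compound 1 to compound 3 (0.10 log units; within the scatter). Compound 4 `O=C(NOCc1ccccc1F)c1cn(-c2ccccc2)nc1-c1ccc(F)cc1` has not been measured; it differs from compound 3 by fluoro in place of hydrogen on an aromatic carbon, the same change, at the same place, as that from compound 1 to compound 2. The expected step for compound 4 in this assay is a 1.1-fold lower number from compound 3 to compound 4 (0.04 log units; within the scatter). Among the compounds with values here, this expectation rests on the single earlier instance, the step from compound 1 to compound 2 of a 1.1-fold lower number from compound 1 to compound 2 (0.03 log units; within the scatter), and on the value of compound 3, 10400 nM. Compound 4 is therefore estimated at 9500 nM, likely between 5000 nM and 18000 nM.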

Compound 4, concentration for 50% growth inhibition: 17500 nM
Compound 4: middle estimate off by 1.8-fold (0.27 log units), on the low side; measured number inside the range.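

In this assay, the change from benzyl to 2-fluorobenzyl, fluoro in place of hydrogen, gave a 1.7-fold higher number from compound 3 to compound 4 (0.23 log units; within the scatter), and fluoro in place of chloro gave a 1.4-fold higher number from compound 2 to compound 4 (0.16 log units; within the scatter). The two instances of the first change do not separate: the same change on two cores in this assay, a 1.1-fold lower number (0.03 log units; within the scatter) from compound 1 to compound 2 and a 1.7-fold higher number (0.23 log units; within the scatter) from compound 3 to compound 4, 1.8-fold (0.26 log units) apart, within the scatter of two such steps. Nor do the two instances of the second, and with every step within the scatter this shows no dependence on the core, but it does not show that either change has a real effect to carry over: the same change on two cores in this assay, a 1.3-fold lower number (0.10 log units; within the scatter) from compound 1 to compound 3 and a 1.4-fold higher number (0.16 log units; within the scatter) from compound 2 to compound 4, 1.8-fold (0.26 log units) apart, within the scatter of two such steps.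

Going by these compounds, whether a methoxy group, an amine or a carboxylic acid in place of the fluoro would give a step beyond the scatter stays open. So does whether the change from benzyl to 2-fluorobenzyl behaves alike on a core bearing a bromo or methyl group in place of the chloro or fluoro.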